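Amide aryl variation on the shared core, compound 4 pending

The source may hold more compounds than are shown below. What is called first, only, known or untested is meant among the compounds shown, and "the series" means these compounds.

The series keeps one core, shown for compound 1 as `O=C(Nc1ccc(Cl)c(-c2nnc3c(Cl)cccn23)c1)c1cccc(Cl)c1`, and varies the aryl on the carbonyl carbon. In a functional assay on AN3-CA cells (Homo sapiens) for antiproliferative activity, read by MTT assay, with a stated time of 72 h (a higher number here means a weaker inhibitor, a lower number a stronger inhibitor), compound 1 gives 68400 nM. Compound 2, `O=C(Nc1ccc(Cl)c(-c2nnc3c(Cl)cccn23)c1)c1c(F)cccc1Cl`, reaches only the limit of the assay, > 100000 nM. Compound 3, `O=C(Nc1ccc(Cl)c(-c2nnc3c(Cl)cccn23)c1)c1ccc(Cl)cc1`, likewise stands at the limit, > 100000 nM. The two steps from compound 1 read an at least 1.4-fold higher number from compound 1 to compound 2 (0.16 log units; that floor lies within the scatter) and an at least 1.4-fold higher number from compound 1 to compound 3 (0.16 log units; that floor lies within the scatter), both floors within the scatter, while a step that the two limits leave unreadable from compound 2 to compound 3 stays unreadable, as the limit of > 100000 nM in this assay, at which 2 of the 3 values shown sit, shows. Compound 4, `CS(=O)(=O)c1ccc(C(=O)Nc2ccc(Cl)c(-c3nnc4c(Cl)cccn34)c2)cc1`, differs from compound 3 by methylsulfonyl in place of chloro on an aromatic carbon. Within the data shown here, no measured step touches this aromatic carbon, so no step bears on it directly. In this assay the expected step is a number no higher from compound 3 to compound 4 (the limit leaves the size open), nothing beyond the scatter. Compound 4 is estimated at 100000 nM, between 40000 nM and 300000 nM.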

Compound 4, half-maximal inhibitory concentration: > 100000 nM
Compound 4 was reported as a limit; the forecaster's own chance of this, stated with the estimate: 55%; the middle value sits exactly at the limit.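

In this assay, methylsulfonyl in place of chloro on this aromatic carbon still yields only a limit for compound 4, > 100000 nM. Among these compounds, the one readable step is an at least 1.4-fold higher number from compound 1 to compound 4 (0.16 log units; that floor lies within the scatter), so it gives no firm separation. The steps to compound 4 from compound 2 and from compound 3 cannot be read, because these values all rest on one limit: the limit of > 100000 nM in this assay, at which 3 of the 4 values shown sit.

As far as these compounds go, the size of any difference among compound 2, compound 3 and compound 4 stays open. Also open, from the compounds shown here alone, is what an amine or a carboxylic acid on this aromatic carbon would give in this assay.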